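From Dimethoxyphenyl to Difluorophenyl on the Shared Core

The source may hold more compounds than are shown below. What is called first, only, known or untested is meant among the compounds shown, and "the series" means these compounds.

For the measured compounds named here, in a functional assay on K562 cells (Homo sapiens) for antiproliferative activity, read by CCK-8 assay, with a stated time of 48 h (a lower number here means a stronger inhibitor, a higher number a weaker inhibitor), compound 1 `COc1ccc(Nc2nc(Nc3cc(C)[nH]n3)cc(N3CCN(C)CC3)n2)cc1OC` gives 462 nM, the higher of the two numbers measured so far. Going by the values given here, the only other measured compound, compound 2 `Cc1cc(Nc2cc(N3CCN(C)CC3)nc(Nc3cccc(F)c3)n2)n[nH]1`, gives 184 nM. Compound 3 `Cc1cc(Nc2cc(N3CCN(C)CC3)nc(Nc3ccc(F)c(F)c3)n2)n[nH]1` has not yet been measured. It keeps the core of compound 1 but carries 3,4-difluorophenyl in place of 3,4-dimethoxyphenyl on a nitrogen on an aromatic ring.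

Among the compounds with values here, only one measured step bears on this change. Replacing the same 3,4-dimethoxyphenyl group with 3-fluorophenyl gave a 2.5-fold lower number from compound 1 to compound 2 (0.40 log units; beyond the scatter), a modest step beyond the scatter. Within the data shown here, no measurement yet shows how 3,4-difluorophenyl itself behaves, so this single step is a limited guide. A step of similar size and direction is nevertheless expected in this assay, towards a lower number. The estimated change is a 2.7-fold lower number from compound 1 to compound 3 (0.43 log units; beyond the scatter). For compound 3, the expected value is 170 nM, with an estimated range from 70 nM to 420 nM.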

Compound 3, half-maximal inhibitory concentration: 195 nM
Beside the measured number, compound 3's estimate is 1.1-fold (0.06 log units) below it; low and high end bracket the measured number.
By their numbers in this assay, from the lowest: compounds 2 and 3 (each within the scatter of the next); then compound 1.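

The 3,4-difluorophenyl group on the nitrogen also reads lower than 3,4-dimethoxyphenyl in this assay, with a 2.4-fold lower number from compound 1 to compound 3 (0.37 log units; beyond the scatter), so the drop seen with 3-fluorophenyl is not confined to that one fluorinated group. Fluoro in place of hydrogen on an aromatic carbon then gives a 1.1-fold higher number from compound 2 to compound 3 (0.03 log units; within the scatter), which lies within the scatter, so compound 2 and compound 3 cannot be told apart here and the further fluoro brings no measurable difference at this position. No accompanying measurement offers an explanation for either result.

The compounds shown leave open how a plain phenyl, a single methoxy, a chloro or a trifluoromethyl group would read on this nitrogen, so the departure of the methoxy groups cannot yet be separated from the arrival of fluoro. They also leave open whether the same replacement would hold on the shared core with a different group in place of the methylpiperazine, or in any cell line other than this one.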